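Swapping a Chlorophenyl for Pyridinyl on the Amide Carbonyl

The compounds below may be only part of what the source reports. "The series", "measured", "known", "first", "only" and "open" are said of these compounds alone.

Compound 1 `Cc1ccc(S(=O)(=O)NCc2ccc(CNC(=O)c3ccc(Cl)cc3)cc2)cc1`: 10 nM
Compound 2 `Cc1ccc(S(=O)(=O)NCc2ccc(CNC(=O)c3cccc(Cl)c3)cc2)cc1`: 100 nM

In an assay on MDA-MB-231 cells for binding affinity to C-X-C chemokine receptor type 4 (Homo sapiens), read by immunofluorescence and microscopy, with stated times of 10 min and 30 min (a lower number here means that less compound is needed, a higher number that more compound is needed for the effect), compound 2 gives 100 nM, the higher of the two numbers, while compound 1 gives 10 nM. Compound 3 `Cc1ccc(S(=O)(=O)NCc2ccc(CNC(=O)c3ccncc3)cc2)cc1` differs from compound 2 by pyridin-4-yl in place of 3-chlorophenyl on a carbonyl carbon. Among the measured compounds shown here, the single measured step, a 10-fold higher number from compound 1 to compound 2 (1.00 log units; beyond the scatter), only moves the chlorine within the ring and does not cover exchanging the chlorophenyl for a pyridinyl ring. For the measured compounds named here, with no step bearing directly on this change, the expected step is a 1.2-fold higher number from compound 2 to compound 3 (0.08 log units; within the scatter), carrying wide uncertainty. Compound 3 is therefore estimated at 120 nM, within 30 nM to 600 nM.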

Compound 3, effective concentration (reported as EC, without a stated level of effect): 10 nM
The estimate for compound 3 lay 12-fold (1.08 log units) above the measured number; measured number below the stated range.
By their numbers in this assay, from the lowest: compounds 1 and 3 (each within the scatter of the next); then compound 2.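

In this assay, pyridin-4-yl on this carbonyl carbon brings a 10-fold lower number from compound 2 to compound 3 (1.00 log units; beyond the scatter), and it gives no change at the digits printed from compound 1 to compound 3 (within the scatter). Among these compounds, then, the ring on the carbonyl carbon needs no chlorine to reach the low number of compound 1, and a ring holding one nitrogen serves as well as 4-chlorophenyl. No available evidence accounts for this result. The compounds shown leave open how pyridin-3-yl, or a phenyl ring carrying an amine or a carboxylic acid, would fare on this carbonyl carbon.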